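From 2-methoxyphenyl to 4-methoxyphenyl: working notes

This account rests on a few compounds, and the source may have more. Where it says the series, first, only, none or still open, it means among the compounds named here.

In a functional assay on MCF7 cells (Homo sapiens) for antiproliferative activity, read by sulforhodamine B assay, with a stated time of 48 h (on this read-out lower numbers stand for stronger inhibition and higher numbers for weaker inhibition), compound 1 `CCN1CCN(c2ccc(S(=O)(=O)Oc3ccccc3OC)cc2)C1=O` gives > 100000 nM, which is a limit of the assay. Among the compounds with values here, compound 2 `CCCCN1CCN(c2ccc(S(=O)(=O)Oc3ccccc3OC)cc2)C1=O` gives 3800 nM, the only actual number so far. Compound 3 `CCCCN1CCN(c2ccc(S(=O)(=O)Oc3ccc(OC)cc3)cc2)C1=O` has 4-methoxyphenyl in place of 2-methoxyphenyl on an oxygen. Within the data shown here, the only measured step, an at least 26-fold lower number from compound 1 to compound 2 (1.42 log units; beyond the scatter), is large but lies in the chain, so it does not bear directly on this change. Among the measured compounds shown here, with no direct precedent, no step beyond the scatter is expected, and the estimated step is a 1.5-fold lower number from compound 2 to compound 3 (0.18 log units; within the scatter). For compound 3 the estimated value is 2500 nM, with an expected range of 400 nM to 15000 nM.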

Compound 3, half-maximal inhibitory concentration: 2500 nM
Compound 3: the middle estimate sits on the measured number at the digits printed; the measured number falls inside the stated range.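

In this assay 4-methoxyphenyl in place of 2-methoxyphenyl gives a 1.5-fold lower number from compound 2 to compound 3 (0.18 log units; within the scatter) and so does not separate the two groups. Within the data shown here, this is the first reading on the oxygen bound to the sulfonyl sulfur, as the only earlier step lay in the chain. No measurement shown gives a reason for this result.

Open, on these data alone, is how 3-methoxyphenyl, unsubstituted phenyl or 4-hydroxyphenyl on the same oxygen would read in this assay and whether the two methoxyphenyl groups would still read alike with a longer chain than that of compound 2.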